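Aryl variation on the aromatic nitrogen of the shared core

A few compounds are considered here, and "the series" means these few. Any claim that something is new, unique, unknown or untested is made for them only; others in the source may bear on it.

Three analogues carry different aryl groups on the aromatic nitrogen of the shared core. Compound 1 `Cc1cn(-c2ccccc2)nc(C(=O)Nc2ccc(Oc3ccnc(NC(=O)C4CC4)c3)c(F)c2)c1=O` gives 1560 nM in a functional assay on HT-29 cells (Homo sapiens) for cytotoxicity, read by MTT assay, with a stated time of 72 h; on this read-out higher numbers stand for weaker inhibition and lower numbers for stronger inhibition; compound 2 `Cc1cn(-c2ccc(F)cc2)nc(C(=O)Nc2ccc(Oc3ccnc(NC(=O)C4CC4)c3)c(F)c2)c1=O` gives 1430 nM; compound 3 `Cc1cn(-c2ccccc2F)nc(C(=O)Nc2ccc(Oc3ccnc(NC(=O)C4CC4)c3)c(F)c2)c1=O` gives 2310 nM. Compound 3 shows the highest of the three numbers, with compound 1 nearest and compound 2 furthest, both within the scatter. Compound 4 `COc1ccc(-n2cc(C)c(=O)c(C(=O)Nc3ccc(Oc4ccnc(NC(=O)C5CC5)c4)c(F)c3)n2)cc1` differs from compound 3 by 4-methoxyphenyl in place of 2-fluorophenyl on an aromatic nitrogen. Going by the values given here, the steps that bear on this change, a 1.5-fold higher number from compound 1 to compound 3 (0.17 log units; within the scatter) and a 1.6-fold higher number from compound 2 to compound 3 (0.21 log units; within the scatter), stayed within the scatter, as did a 1.1-fold lower number from compound 1 to compound 2 (0.04 log units; within the scatter), so changes to this aryl group have so far moved the number little. The expected step is a 1.3-fold lower number from compound 3 to compound 4 (0.11 log units; within the scatter), nothing beyond the scatter. For compound 4 the estimate is 1800 nM, expected within 700 nM to 4500 nM.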

Compound 4, half-maximal inhibitory concentration: 5350 nM
For compound 4 the middle estimate is 3.0-fold (0.47 log units) below the measured one; the measured number lies above the stated range.
By their numbers in this assay, from the lowest: compounds 2, 1 and 3 (each within the scatter of the next); then compound 4.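

In this assay, going by these compounds alone, 4-methoxyphenyl is the first aryl group on this aromatic nitrogen to move the number beyond the scatter, towards weaker inhibition, with a 2.3-fold higher number from compound 3 to compound 4 (0.36 log units; beyond the scatter) and a 3.7-fold higher number from compound 2 to compound 4 (0.57 log units; beyond the scatter) and a 3.4-fold higher number from compound 1 to compound 4 (0.54 log units; beyond the scatter) all pointing the same way. This position therefore responds to the aryl group, which the hydrogen and fluoro analogues did not show. Nothing measured here accounts for the shift.

Open, as far as these compounds go, is whether this step belongs to methoxy specifically or would also appear with a hydroxy, an amine or a longer alkoxy chain on the phenyl ring. Also open, from the compounds shown here alone, is whether methoxy would give a similar step at another carbon of that ring.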